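A few compounds are considered here, and "the series" means these few. Any claim that something is new, unique, unknown or untested is made for them only; others in the source may bear on it.

Measured in a functional assay on KBVIN cells (Homo sapiens) for antiproliferative activity, read by sulforhodamine B assay, with a stated time of 3 days; on this read-out lower numbers stand for an effect already at smaller amounts and higher numbers for an effect only at larger amounts of compound:

- Compound 1 `CCC1=C(O)c2c(oc(-c3ccc(CC)cc3)cc2=O)C(CC)(CC)C1=O`: 0.07 uM
- Compound 2 `CCC1=C(O)c2c(oc(-c3ccc(C)c(F)c3)cc2=O)C(CC)(CC)C1=O`: 2.95 uM
- Compound 3 `CCC1=C(O)c2c(oc(-c3ccc(OC)c(C)c3)cc2=O)C(CC)(CC)C1=O`: 0.1 uM

Compound 3 belongs at the low end of this small set, together with compound 1. The gap between those two is small: a 1.4-fold higher number from compound 1 to compound 3 (0.15 log units; within the scatter). Compound 2 stands well apart, as the other gap shows: a 30-fold lower number from compound 2 to compound 3 (1.47 log units; beyond the scatter).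

The next compound is compound 4 `CCC1=C(O)c2c(oc(-c3cccc(C)c3C)cc2=O)C(CC)(CC)C1=O`, which keeps the shared core and has 2,3-dimethylphenyl in place of 4-methoxy-3-methylphenyl on an aromatic carbon.

Among the compounds with values here, all the measured steps alter this same aryl group, so all of them bear on the question. They point in different directions. One swap barely registers, yet another gives a 42-fold higher number from compound 1 to compound 2 (1.62 log units; beyond the scatter). Such a swap can therefore be silent or large, and no measured compound carries 2,3-dimethylphenyl. Within the data shown here, with only compound 1 and compound 3 holding low numbers, and compound 2 at 2.95 uM as the one example of a departure, a moderate rise in this assay is the expectation, with wide uncertainty.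

The estimated move is a 7.0-fold higher number from compound 3 to compound 4 (0.85 log units; beyond the scatter). For compound 4 the expected value is 0.7 uM, with an estimated range from 0.12 uM to 4 uM.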

Compound 4, concentration for half-maximal effect: 0.85 uM
Beside the measured number, compound 4's estimate is 1.2-fold (0.08 log units) below it, and the stated range covers the measured number.
By their numbers in this assay, from the lowest: compounds 1 and 3 (each within the scatter of the next); then compound 4; then compound 2.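

Compound 4 opens a middle level in what had been a split between low numbers and one high outlier: in this assay, 2,3-dimethylphenyl gives an 8.5-fold higher number from compound 3 to compound 4 (0.93 log units; beyond the scatter) and a 12-fold higher number from compound 1 to compound 4 (1.08 log units; beyond the scatter), yet it still gives a 3.5-fold lower number from compound 2 to compound 4 (0.54 log units; beyond the scatter). This aryl position therefore allows graded changes, not only a choice between keeping and losing the effect. Removing the oxygen of 4-methoxy-3-methylphenyl cannot by itself set the level, since 4-ethylphenyl also has no oxygen and compound 1 stays at the low end, and carrying two groups on the aryl ring does not set it either, as compound 2, compound 3 and compound 4 all do so but differ widely.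

Nothing here explains why these aryl groups differ, as no supporting measurement accompanies the numbers. From the compounds shown here alone, it remains open whether a longer chain, as in 4-propylphenyl, or an amine, as in 4-aminophenyl, would keep the low numbers of compound 1 and compound 3 or move towards compound 4 and compound 2.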